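The source may hold more compounds than are shown below. What is called first, only, known or untested is meant among the compounds shown, and "the series" means these compounds.

Compound 1, `CC(C)c1ccc(-c2nc(SCc3cn(CC(=O)NC(=O)Nc4ccccn4)nn3)nc(Nc3ccccc3Cl)c2C#N)cc1`, gives 6790 nM in a functional assay on B16-F10 cells (Mus musculus) for inhibition, read by MTT assay, with a stated time of 72 h; a higher number here means a weaker inhibitor, a lower number a stronger inhibitor. Compound 2, `CC(C)c1ccc(-c2nc(SCc3cn(CC(=O)NC(=O)Nc4ccccn4)nn3)nc(Nc3cccc(C(F)(F)F)c3)c2C#N)cc1`, gives 1700 nM. Compound 3, `CC(C)c1ccc(-c2nc(SCc3cn(CC(=O)NC(=O)Nc4ccccn4)nn3)nc(Nc3ccccc3F)c2C#N)cc1`, gives 8380 nM.

Compound 2 stands lowest of the three numbers in this assay: the step of a 4.0-fold lower number from compound 1 to compound 2 (0.60 log units; beyond the scatter) and the step of a 4.9-fold higher number from compound 2 to compound 3 (0.69 log units; beyond the scatter) both go beyond the scatter, while the step of a 1.2-fold higher number from compound 1 to compound 3 (0.09 log units; within the scatter) stays within it. Compound 4, `Cc1ccc(Nc2nc(SCc3cn(CC(=O)NC(=O)Nc4ccccn4)nn3)nc(-c3ccc(C(C)C)cc3)c2C#N)cc1`, has not yet been measured. It differs from compound 2 in one place: 4-methylphenyl in place of 3-(trifluoromethyl)phenyl on a nitrogen on an aromatic ring. The two measured steps that bear on this change are those in which the 3-(trifluoromethyl)phenyl on that nitrogen is exchanged for another phenyl, and both gave modest rises in the number. Within the data shown here, no measured step covers 4-methylphenyl itself, so the direction rests on the two rings already seen. A modest rise is therefore expected, as a 2.6-fold higher number from compound 2 to compound 4 (0.42 log units; beyond the scatter). For compound 4 the estimate in this assay is 4500 nM, with a range from 1700 nM to 12000 nM.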

Compound 4, half-maximal inhibitory concentration: 3060 nM
For compound 4 the middle estimate is 1.5-fold (0.17 log units) above the measured one; measured number inside the range.
By their numbers in this assay, from the lowest: compounds 2 and 4 (each within the scatter of the next); then compounds 1 and 3 (each within the scatter of the next).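

In this assay, a 1.8-fold higher number from compound 2 to compound 4 (0.26 log units; within the scatter) shows that the low numbers at this nitrogen do not depend on the 3-(trifluoromethyl)phenyl: the 4-methylphenyl, which carries no fluorine, stays within the scatter of it. The new ring also separates from both halogen-bearing rings with an ortho-free... 

Correction, final text:

In this assay, a 1.8-fold higher number from compound 2 to compound 4 (0.26 log units; within the scatter) shows that the low numbers on this nitrogen do not depend on the 3-(trifluoromethyl)phenyl, since a 4-methylphenyl, with only carbon among its heavy atoms, stays within the scatter of it. The 4-methylphenyl also stands apart from both other rings, with a 2.2-fold lower number from compound 1 to compound 4 (0.35 log units; beyond the scatter) and a 2.7-fold lower number from compound 3 to compound 4 (0.44 log units; beyond the scatter), so compounds 2 and 4 now form a pair set off from compounds 1 and 3. Nothing available gives a reason for these differences.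

The compounds shown leave open whether the group itself or its place on the ring sets the number, as none of them carries one group at two places. As far as these compounds go, whether a 4-methoxyphenyl or a phenyl bearing a carboxylic acid would join compounds 2 and 4 also stays open.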